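Swapping the amide cap on a bis-sulfonamide piperidine

The compounds below may be only part of what the source reports. "The series", "measured", "known", "first", "only" and "open" are said of these compounds alone.

Of the compounds shown here, three have so far been tested in a functional assay on MIA PaCa-2 cells (Homo sapiens) for inhibition, read by MTT assay, with a stated time of 7 days; a lower number here means a stronger inhibitor, a higher number a weaker inhibitor. Compound 1 `CCOC(=O)[C@@H]1CCC[C@@H](S(=O)(=O)c2ccc(S(=O)(=O)N(CC)CC)cc2)C1` gives 16400 nM, compound 3 `CCOC(=O)[C@@H]1C[C@@H](O)CN(S(=O)(=O)c2ccc(S(=O)(=O)N(CC)CC)cc2)C1` gives 7900 nM, and compound 2 `CCN(CC)S(=O)(=O)c1ccc(S(=O)(=O)N2CCC[C@@H](C(=O)NC3CN(C(=O)C4CC4)C3)C2)cc1` gives 2800 nM. Compound 2 is the strongest inhibitor of the three, since both compound 3 and compound 1 sit beyond the usual scatter above it, compound 1 furthest of all.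

Compound 4 `CCN(CC)S(=O)(=O)c1ccc(S(=O)(=O)N2CCC[C@@H](C(=O)N[C@H]3CCN(C(=O)OC(C)(C)C)C3)C2)cc1` has not yet been measured. It differs from compound 2 by 1-(tert-butoxycarbonyl)pyrrolidin-3-yl in place of 1-(cyclopropylcarbonyl)azetidin-3-yl on an amide-type nitrogen. For the measured compounds named here, no measured pair shows this change, so its effect is unknown from these data. The step of a 1.1-fold higher number from compound 2 to compound 4 (0.03 log units; within the scatter) is expected to be small, no larger than the scatter in either direction. The estimate for compound 4 is 3000 nM, within a range from 800 nM to 12000 nM.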

Compound 4, half-maximal inhibitory concentration: 100 nM
Compound 4: middle estimate off by 30-fold (1.48 log units), on the high side, and the stated range ends above it.
By their numbers in this assay, from the lowest: compound 4; then compound 2; then compound 3; then compound 1.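

For the compounds shown here, this amide-type nitrogen is far more sensitive to its substituent than the earlier compounds could show: in this assay the 1-(tert-butoxycarbonyl)pyrrolidin-3-yl group gives a 28-fold lower number from compound 2 to compound 4 (1.45 log units; beyond the scatter) in place of 1-(cyclopropylcarbonyl)azetidin-3-yl. Ring and cap change together here, so this single step cannot assign the gain to either one. No measured information explains the gain.

Going by these compounds, it remains open whether the five-membered ring, the tert-butoxycarbonyl cap or the defined stereocentre carries the step. A cyclopropylcarbonyl cap on the five-membered ring, or a free amine there instead of any cap, would help separate these parts.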